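Trading a cyclohexyl ring for a heptyl chain

A few compounds are considered here, and "the series" means these few. Any claim that something is new, unique, unknown or untested is made for them only; others in the source may bear on it.

Compound 1 `Cc1[nH]c(=O)n(C)c1-c1ccc(OC(C)C)cc1`: 20400 nM
Compound 2 `Cc1[nH]c(=O)n(C)c1-c1ccc(CC(C)C)cc1`: 7800 nM
Compound 3 `Cc1[nH]c(=O)n(C)c1-c1ccc(C2CCCCC2)cc1`: 10000 nM

In a functional assay on brain (Rattus norvegicus, strain Wistar) for inhibition (a lower number here means a stronger inhibitor, a higher number a weaker inhibitor), compound 3 gives 10000 nM, which matches compound 2 within the scatter and is a lower number than compound 1. Compound 4 `CCCCCCCc1ccc(-c2c(C)[nH]c(=O)n2C)cc1` carries heptyl in place of cyclohexyl on an aromatic carbon. The closest guide is a 1.3-fold higher number from compound 2 to compound 3 (0.11 log units; within the scatter), a swap between two groups of carbon only. Replacing isopropoxy gave modest steps: a 2.6-fold lower number from compound 1 to compound 2 (0.42 log units; beyond the scatter) and a 2.0-fold lower number from compound 1 to compound 3 (0.31 log units; beyond the scatter). No step beyond the scatter is therefore expected in this assay, though no chain as long as heptyl has been measured. The estimated step is a 1.3-fold lower number from compound 3 to compound 4 (0.12 log units; within the scatter). For compound 4 the estimate is 7500 nM, with an expected range of 2500 nM to 20000 nM.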

Compound 4, half-maximal inhibitory concentration: 8400 nM
Compound 4: the middle estimate sits 1.1-fold (0.05 log units) below what was measured; measured number inside the range.
By their numbers in this assay, from the lowest: compounds 2, 4 and 3 (each within the scatter of the next); then compound 1.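

In this assay, a long straight chain does no differently from a ring at this position: heptyl in place of cyclohexyl gives a 1.2-fold lower number from compound 3 to compound 4 (0.08 log units; within the scatter), and hexyl in place of isopropyl on a saturated chain carbon gives a 1.1-fold higher number from compound 2 to compound 4 (0.03 log units; within the scatter). Heptyl also holds the modest edge over the isopropoxy compound, with a 2.4-fold lower number from compound 1 to compound 4 (0.39 log units; beyond the scatter). Nothing available explains this result. Still open, as far as these compounds go, is whether a longer chain would finally move the number beyond the scatter. An amine or a carboxylic acid in this place also remains untested among the compounds shown.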